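This account rests on a few compounds, and the source may have more. Where it says the series, first, only, none or still open, it means among the compounds named here.

Measured so far in a functional assay on HCT-116 cells (Homo sapiens) for inhibition, read by luminescence and resazurin assay, with a stated time of 3 days; on this read-out higher numbers stand for weaker inhibition and lower numbers for stronger inhibition:
compound 1 `CN1CCN(c2nc(NCc3ccc(NC(=O)c4ccncc4)cc3)c3ccccc3n2)CC1` gives > 20000 nM
compound 2 `CNc1nc(NCc2ccc(NC(=O)c3ccc(F)cc3)cc2)c2ccccc2n1` gives 1600 nM
compound 3 `Cc1ccc2nc(N(C)C)nc(NCc3ccc(C(=O)NC4CCN(Cc5ccc(F)cc5)CC4)cc3)c2c1` gives 800 nM

Compound 1 gives only a limit of this assay and no number: the limit of > 20000 nM in this assay, at which 1 of the 3 values shown sits. Of the two numbers, compound 3 has the lower one, but compound 2 lies within the scatter of it, so no order between the two is claimed.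

Compound 4 `CCCNc1nc(NCc2ccc(C(=O)NC3CCN(Cc4ccc(F)cc4)CC3)cc2)c2cc(C)ccc2n1` differs from compound 3 by propylamino in place of dimethylamino on an aromatic carbon. Among the compounds with values here, no measured pair shows this change, so in this assay no step beyond the scatter is expected in either direction. For compound 4 the expected value is 700 nM, with a range from 250 nM to 2000 nM. The expected step is a 1.1-fold lower number from compound 3 to compound 4 (0.06 log units; within the scatter), within the scatter.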

Compound 4, half-maximal inhibitory concentration: 1600 nM
Compound 4: middle estimate off by 2.3-fold (0.36 log units), on the low side; measured number inside the range.
By their numbers in this assay, from the lowest: compounds 3, 2 and 4 (each within the scatter of the next). At a limit, above all of these: compound 1.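

In this assay, within the data shown here, placing propylamino, with its hydrogen-bond donor, in place of dimethylamino on the aromatic carbon between two ring nitrogen atoms gives a 2.0-fold higher number from compound 3 to compound 4 (0.30 log units; within the scatter) as the first single-place comparison. At this position, the read-out does not separate the two groups. Nothing measured here gives a cause for this step.

Still open, going by these compounds, is whether a morpholine ring, a carboxylic acid or a longer alkyl chain at this carbon would move the number beyond the scatter.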